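Benzyl for Ethyl on the Amine: An Unmeasured Step

The compounds below may be only part of what the source reports. "The series", "measured", "known", "first", "only" and "open" are said of these compounds alone.

Compound 1 `CCN(CCCCOc1ccc(/C=C/C(=O)c2ccc(N(C)C)cc2O)cc1)Cc1ccccc1N(C)C`, 4300 nM
Compound 2 `CCN(CC)CCCOc1ccc(C(=O)/C=C/c2ccc(N(C)C)cc2)c(O)c1`, 4100 nM

Of the compounds shown here, two have been measured in an assay on isolated protein for inhibition of Amine oxidase [flavin-containing] B (Homo sapiens); on this read-out lower numbers stand for stronger inhibition and higher numbers for weaker inhibition. Compound 1 `CCN(CCCCOc1ccc(/C=C/C(=O)c2ccc(N(C)C)cc2O)cc1)Cc1ccccc1N(C)C` gives 4300 nM, and compound 2 `CCN(CC)CCCOc1ccc(C(=O)/C=C/c2ccc(N(C)C)cc2)c(O)c1` gives 4100 nM. The gap between the two values lies within the scatter of this assay, so compound 2 stands level with compound 1 rather than apart from it.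

Compound 3 `CCN(CCCOc1ccc(C(=O)/C=C/c2ccc(N(C)C)cc2)c(O)c1)Cc1ccc(N(C)C)cc1` has not been measured. It differs from compound 2 by 4-(dimethylamino)phenyl in place of methyl on a saturated chain carbon bound to an amine nitrogen; cut one bond further out, the change reads ethyl to 4-(dimethylamino)benzyl. Within the data shown here, no step between measured compounds speaks to this change. Compound 1, which carries a benzyl with a dimethylamino group on its amine and gives 4300 nM, sits level with compound 2, so no step beyond the scatter is expected from compound 2 to compound 3. Compound 3 is therefore estimated at 3500 nM, with a range from 1200 nM to 10000 nM, meaning an expected step of a 1.2-fold lower number from compound 2 to compound 3 (0.07 log units; within the scatter).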

Compound 3, half-maximal inhibitory concentration: 13700 nM
Compound 3: middle estimate off by 3.9-fold (0.59 log units), on the low side; the whole stated range lies below it.
By their numbers in this assay, from the lowest: compounds 2 and 1 (each within the scatter of the next); then compound 3.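

In this assay, the saturated chain carbon bound to an amine nitrogen now has a step of its own: 4-(dimethylamino)phenyl in place of methyl gives a 3.3-fold higher number from compound 2 to compound 3 (0.52 log units; beyond the scatter). This step is modest but beyond the scatter, so the change from ethyl to 4-(dimethylamino)benzyl weakens inhibition here. Compounds 1 and 2 could not show this, as they differ in more than one place and their level values say nothing about this change alone. Nothing at hand accounts for the weakening.

The compounds shown leave open whether the weaker inhibition goes with the benzyl itself or with the dimethylamino group it carries, a question that an unsubstituted benzyl on the same amine would address. Going by these compounds, it also remains open whether a methoxy group in place of that dimethylamino group would give a similar number.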